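Series notes: varying the aryl group on the alkene

The source may report more compounds than this note shows. Statements on the series, on what has been measured and on what is new or still open speak of the compounds shown alone.

Compound 1 `O=S(=O)(/C=C/c1ccc(F)cc1)Cc1ccc(Nc2ncnc3ccccc23)cc1` is the reference. In a functional assay on OVCAR-8 cells (Homo sapiens) (a higher number here means a weaker inhibitor of growth, a lower number a stronger inhibitor of growth), compound 1 gives 2000 nM, the lowest of the two numbers recorded; compound 2 `O=S(=O)(/C=C/c1ccc(Cl)c(Cl)c1)Cc1ccc(Nc2ncnc3ccccc23)cc1` gives 14000 nM. Compound 3 `O=S(=O)(/C=C/c1ccc(Cl)cc1)Cc1ccc(Nc2ncnc3ccccc23)cc1` reaches only the assay limit, > 100000 nM (the limit of > 100000 nM in this assay, at which 1 of the 3 values shown sits). Among the measured pairs, an at least 7.1-fold higher number from compound 2 to compound 3 (0.85 log units; beyond the scatter). Compound 4 `O=S(=O)(/C=C/c1ccc(C(F)(F)F)cc1F)Cc1ccc(Nc2ncnc3ccccc23)cc1` is not yet measured; it differs from compound 1 thus: 2-fluoro-4-(trifluoromethyl)phenyl in place of 4-fluorophenyl on a double-bonded chain carbon bound to a double-bonded chain carbon. Going by the values given here, the steps that bear on this change are a 7.0-fold higher number from compound 1 to compound 2 (0.85 log units; beyond the scatter) and an at least 50-fold higher number from compound 1 to compound 3 (1.69 log units; beyond the scatter), both going the same way, so an upward step beyond the scatter is expected for compound 4 in this assay, estimated as a 7.5-fold higher number from compound 1 to compound 4 (0.88 log units; beyond the scatter). Compound 4 is accordingly expected near 15000 nM, with a range from 3000 nM to 80000 nM.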

Compound 4, concentration for 50% growth inhibition: 100000 nM
Beside the measured number, compound 4's estimate is 6.7-fold (0.82 log units) below it; measured number above the stated range.
By their numbers in this assay, from the lowest: compound 1; then compound 2; then compound 4.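

In this assay, 2-fluoro-4-(trifluoromethyl)phenyl in place of 4-fluorophenyl gives a 50-fold higher number from compound 1 to compound 4 (1.70 log units; beyond the scatter). All three replacements of 4-fluorophenyl shown go the same way, with none against. The step to this group from 3,4-dichlorophenyl also goes upward, with a 7.1-fold higher number from compound 2 to compound 4 (0.85 log units; beyond the scatter). The step to this group from 4-chlorophenyl gives only a number no higher from compound 3 to compound 4 (the limit leaves the size open), and its size cannot be read. Compound 3 stands at a limit: the limit of > 100000 nM in this assay, at which 1 of the 4 values shown sits.

The separate shares of the fluoro and the trifluoromethyl in 2-fluoro-4-(trifluoromethyl)phenyl stay unresolved. As far as these compounds go, whether an amine or a carboxylic acid on this ring would bring the number under that of compound 1 stays open.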